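A few compounds are considered here, and "the series" means these few. Any claim that something is new, unique, unknown or untested is made for them only; others in the source may bear on it.

Measured so far:
Compound 1, `COc1cc(/C=N/Nc2nc(-c3ccc(Br)cc3)cs2)cc(Br)c1OC`. In an ADME assay on HUVEC cells (Homo sapiens) for inhibition, read by MTT assay, with a stated time of 48 h (a lower number here means a stronger inhibitor, a higher number a weaker inhibitor), compound 1 gives > 100000 nM, which is a limit of the assay and not a number.
Compound 2, `COc1cc(/C=N/Nc2nc(-c3cccc(Br)c3)cs2)cc(Br)c1OC`. In this assay compound 2 gives > 100000 nM, again a limit and not a number.

Compound 2 thus stands at the limit: the limit of > 100000 nM in this assay, at which 2 of the 2 values shown sit. For the measured compounds named here, the one measured step, a step that the two limits leave unreadable from compound 1 to compound 2, is likewise unreadable, so nothing about its size is known.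

Compound 3 is `COc1cc(/C=N/Nc2nc(-c3ccc(F)c(F)c3)cs2)cc(Br)c1OC`. It differs from compound 2 by 3,4-difluorophenyl in place of 3-bromophenyl on an aromatic carbon. Going by the values given here, no measured step bears on this change, since the only step on record cannot be read. The step from compound 2 to compound 3 in this assay is therefore expected to be a step that the limit leaves unreadable from compound 2 to compound 3, that is, no shift that can be told from a limit. Compound 3 is estimated at 150000 nM, with a range from 50000 nM to 500000 nM, and the most likely outcome is expected to be once more a limit rather than a number.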

Compound 3, half-maximal inhibitory concentration: > 100000 nM
Compound 3: a limit, no number; the forecaster's own chance of this, stated with the estimate: 80%; the middle value is on the limit's open side.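

No step among compound 1, compound 2 and compound 3 can be read, because each stands at a limit and not at a number: the limit of > 100000 nM in this assay, at which 3 of the 3 values shown sit.

The compounds shown leave open how 4-bromophenyl, 3-bromophenyl and 3,4-difluorophenyl rank against one another in this assay.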